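A few compounds are considered here, and "the series" means these few. Any claim that something is new, unique, unknown or untested is made for them only; others in the source may bear on it.

Measured in a functional assay on HepG2 cells (Homo sapiens) for inhibition, read by MTT assay, with a stated time of 48 h; on this read-out lower numbers stand for stronger inhibition and higher numbers for weaker inhibition:
- Compound 1 `COc1cc(-c2nnc(S)n2-c2ccc(N(C)C)cc2)cc(OC)c1OC`: > 60000 nM (a limit)
- Compound 2 `COc1cc(-c2nnc(SCc3ccccc3)n2-c2ccc(N(C)C)cc2)cc(OC)c1OC`: > 60000 nM (a limit)

Compound 2 has no number in this assay, only the limit > 60000 nM. The next compound, compound 3 `COc1cc(-c2nnc(SCC(=O)c3ccc(F)cc3)n2-c2ccc(N(C)C)cc2)cc(OC)c1OC`, keeps the shared core and the sulfur and changes only the group on the chain carbon: (4-fluorophenyl)carbonyl in place of phenyl on a saturated chain carbon bound to a sulfur. The new group therefore brings a carbonyl and a fluorine into the side chain.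

Among the compounds with values here, only one measured step bears on this change, a step that the two limits leave unreadable from compound 1 to compound 2. It gives no size, and both compounds sit at the same ceiling, as shown by the limit of > 60000 nM in this assay, at which 2 of the 2 values shown sit. Nothing measured therefore predicts a large step in this assay. Within the data shown here, the expectation is that compound 3 also stays near this ceiling, with a modest move towards stronger inhibition as the only likely change, and a real chance that again only a limit is reported. The step expected here is an at least 1.2-fold lower number from compound 2 to compound 3 (0.07 log units; that floor lies within the scatter). For compound 3 the estimated value is 50000 nM, with an expected range from 12000 nM to 120000 nM.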

Compound 3, half-maximal inhibitory concentration: > 60000 nM
Compound 3: a limit, no number; the forecaster's own chance of this, stated with the estimate: 60%; at least 1.2-fold (0.07 log units) between middle value and limit.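

No step can be read among compound 1, compound 2 and compound 3 in this assay, because each of the three carries only a limit and no number: the limit of > 60000 nM in this assay, at which 3 of the 3 values shown sit. The compounds shown leave open how strongly any of these groups on the sulfur changes inhibition, and whether any group there would give a measurable number in this assay.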